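Phenoxymethyl benzamide series: antiproliferative read-out, trifluoromethyl variant

This account rests on a few compounds, and the source may have more. Where it says the series, first, only, none or still open, it means among the compounds named here.

Two compounds of the series carry a measured number. In a functional assay on MIA PaCa-2 cells (Homo sapiens) for antiproliferative activity, read by MTT assay, with a stated time of 72 h (on this read-out lower numbers stand for an effect already at smaller amounts and higher numbers for an effect only at larger amounts of compound), compound 1 `CCNC(=O)c1cccc(Cn2nc(C)c(NC(=O)c3ccc(COc4ccccc4)cc3)c2C)c1` gives 11000 nM, and compound 2 `CNC(=O)c1cccc(Cn2nc(C)c(NC(=O)c3ccc(COc4ccc(C)cc4)cc3)c2C)c1` gives 2600 nM. Compound 2 therefore stands at the lowest number of the two; compound 1 sits at a value beyond the scatter above it. Going by the values given here, the two compounds differ in more than one place, so no single step can be assigned between them.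

Compound 3 `CNC(=O)c1cccc(Cn2nc(C)c(NC(=O)c3ccc(COc4ccccc4C(F)(F)F)cc3)c2C)c1` is the next variant of compound 2. The change is 2-(trifluoromethyl)phenyl in place of 4-methylphenyl on an oxygen on a saturated carbon. Among the compounds with values here, no pair of measured compounds shows this kind of exchange, so nothing in the data fixes its size or direction. The working expectation is a step in this assay of a 1.3-fold higher number from compound 2 to compound 3 (0.13 log units; within the scatter), which is no change beyond the scatter. Compound 3 is accordingly estimated in this assay at 3500 nM, within the range 1200 nM to 10000 nM.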

Compound 3, half-maximal effective concentration: 10000 nM
Compound 3: middle estimate off by 2.9-fold (0.46 log units), on the low side; the measured number falls inside the stated range.
By their numbers in this assay, from the lowest: compound 2; then compounds 3 and 1 (each within the scatter of the next).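

On the aryl group held by the oxygen on a saturated carbon, this assay gives the series its first readable single-place step: 2-(trifluoromethyl)phenyl in place of 4-methylphenyl brings a 3.8-fold higher number from compound 2 to compound 3 (0.59 log units; beyond the scatter). This position is therefore not indifferent to the group it carries, which compounds 1 and 2 could not show, since they differ in more than one place. Nothing at hand accounts for the size or direction of this step.

Still open, on these data alone, is whether the higher number goes with the trifluoromethyl group itself or with the change from the 4-substituted to the 2-substituted phenyl, since the two change together in this step. Also open, as far as these compounds go, is how this read-out responds when the phenyl carries an amine or a carboxylic acid.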